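The compounds below may be only part of what the source reports. "The series", "measured", "known", "first", "only" and "open" are said of these compounds alone.

Measured so far in an assay on HEK-293T cells for inhibition of diacylglycerol lipase-alpha (Homo sapiens), read by colorimetric assay; on this read-out higher numbers stand for weaker inhibition and lower numbers for stronger inhibition:
compound 1, `CCCCCC(=O)c1nc2ncccc2o1`, gives a limit of > 10000 nM.
compound 2, `C=CCCCCCCCC(=O)c1nc2ncccc2o1`, gives 550 nM.

Compound 2 carries the only number shown in this assay; the value of compound 1 in that assay is a limit rather than a number, as noted in the limit of > 10000 nM in this assay, at which 1 of the 2 values shown sits. Within the data shown here, the one measured step, an at least 18-fold lower number from compound 1 to compound 2 (1.25 log units; beyond the scatter), is large and beyond the scatter: lengthening the acyl chain by but-3-en-1-yl moved compound 2 from the limit down to a measured number.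

Compound 3, `CCCCCCCCCCCCCC(=O)c1nc2ncccc2o1`, differs from compound 2 by hexyl in place of vinyl on a saturated chain carbon, seven bonds along the chain from a carbonyl carbon. Among the measured compounds shown here, only the step of an at least 18-fold lower number from compound 1 to compound 2 (1.25 log units; beyond the scatter) bears on this change, and it points the same way, since compound 3 again extends the chain, though it also gives up the terminal double bond that compound 2 carries. For the measured compounds named here, no measured pair here separates the effect of chain length from that of the double bond. On that basis a further modest gain, or no change beyond the scatter, is expected for compound 3 in this assay. Compound 3 is therefore estimated at 250 nM, within 50 nM to 1500 nM, which is an expected step of a 2.2-fold lower number from compound 2 to compound 3 (0.34 log units; beyond the scatter).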

Compound 3, half-maximal inhibitory concentration: 74.1 nM
Estimate against measurement, compound 3: 3.4-fold (0.53 log units) above; the range from low to high includes it.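

In this assay, hexyl in place of vinyl gives a 7.4-fold lower number from compound 2 to compound 3 (0.87 log units; beyond the scatter), which shows that, among the compounds shown, the double bond of compound 2 is not needed for a measured number, since compound 3 has none outside aromatic rings and still gives the lowest number of the three. Taken from the shortest acyl chain shown, octyl in place of hydrogen gives an at least 130-fold lower number from compound 1 to compound 3 (2.13 log units; beyond the scatter), and across the three compounds the number falls as the chain grows, with no compound going against that order. Compound 1 stands at a limit rather than a number, so this step gives only a bound on the size of the change: the limit of > 10000 nM in this assay, at which 1 of the 3 values shown sits.

Chain length and the double bond change together in the one step between the two measured numbers, so what each contributes on its own remains open, and a saturated chain matched in length to that of compound 2 would be needed to separate them. Also open, from the compounds shown here alone, is whether a longer chain than that of compound 3 lowers the number further, and how a carboxylic acid or a phenyl group on the chain would compare.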